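From methyl to bromo in one small series

A few compounds are considered here, and "the series" means these few. Any claim that something is new, unique, unknown or untested is made for them only; others in the source may bear on it.

Measured in a functional assay on MCF7 cells (Homo sapiens) for antiproliferative activity, read by MTT assay, with a stated time of 48 h; a higher number here means a weaker inhibitor, a lower number a stronger inhibitor:
- compound 1 `O=C(/C=C/c1ccc(C(F)(F)F)cc1)Nc1nnc(-c2ccc(Br)cc2)s1`: 1.58 ug/mL
- compound 2 `Cc1ccc(/C=C/C(=O)Nc2nnc(-c3ccc(C)cc3)s2)cc1`: 0.61 ug/mL
- compound 3 `Cc1ccc(-c2nnc(NC(=O)/C=C/c3ccccc3)s2)cc1`: 1.19 ug/mL

Compound 2 gives 0.61 ug/mL and sits at the low end of these numbers, level with compound 3 within the scatter. Only compound 1 differs from it beyond the scatter, with a higher number.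

Compound 4 `Cc1ccc(/C=C/C(=O)Nc2nnc(-c3ccc(Br)cc3)s2)cc1` has not been measured yet. It differs from compound 2 by one change: bromo in place of methyl on an aromatic carbon.

Going by the values given here, the only measured single-place step is a 2.0-fold higher number from compound 2 to compound 3 (0.29 log units; within the scatter). It removes a methyl, but not the one that bromo replaces here, so it is a loose guide. Among the compounds with values here, compound 1 also carries the 4-bromophenyl group, and its 1.58 ug/mL hints at a small rise, though no measured step isolates the bromo.

In this assay, a small upward move that stays within the scatter is therefore expected, with an estimated 1.5-fold higher number from compound 2 to compound 4 (0.17 log units; within the scatter). For compound 4 the estimated value is 0.9 ug/mL, with an expected range from 0.4 ug/mL to 2 ug/mL.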

Compound 4, half-maximal inhibitory concentration: 1.32 ug/mL
The estimate for compound 4 lay 1.5-fold (0.17 log units) below the measured number, and the stated range covers the measured number.
By their numbers in this assay, from the lowest: compounds 2, 3, 4 and 1 (each within the scatter of the next, the first and the last beyond it).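

In this assay, going by these compounds alone, the step of a 2.2-fold higher number from compound 2 to compound 4 (0.34 log units; beyond the scatter) is the first single-place change at this position, where 4-methylphenyl becomes 4-bromophenyl. It is modest but lies beyond the scatter, so the number responds to which group sits here, something the earlier step, which removed the other methyl, could not show. With the 4-bromophenyl group in place, exchanging trifluoromethyl for methyl gives a 1.2-fold lower number from compound 1 to compound 4 (0.08 log units; within the scatter) and stays within the scatter, and nothing available explains either result.

Going by these compounds, what an amine or a carboxylic acid would do on this same aromatic carbon stays open. So does whether the move from methyl to bromo keeps its size when trifluoromethyl or hydrogen occupies the other aromatic ring.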